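The source may report more compounds than this note shows. Statements on the series, on what has been measured and on what is new or still open speak of the compounds shown alone.

Measured compounds in an assay on a protein complex for inhibition of CDK8/Cyclin C (Homo sapiens), with a stated time of 1 h; a lower number here means a stronger inhibitor, a higher number a weaker inhibitor:
compound 1 `COC1CN(C(=O)/C=C/c2ccncc2-c2ccc3ccccc3c2)C1` gives 42.8 nM
compound 2 `COc1ccc(-c2cnccc2/C=C/C(=O)N2CC(OC)C2)cc1OC` gives 1220 nM
compound 3 `O=C(/C=C/c1ccncc1-c1ccc2[nH]ccc2c1)N1CCOCC1` gives 190 nM

Of these three, compound 1 has the lowest number; compound 3 is nearest and compound 2 furthest, and both gaps lie beyond the scatter, so compound 1 is the strongest inhibitor of the set in this assay. Compound 4 `CNC(=O)/C=C/c1ccncc1-c1ccc2ccccc2c1` keeps the core of compound 1 and alters only the amide: methylamino in place of 3-methoxyazetidin-1-yl on a carbonyl carbon. Going by the values given here, no measured pair shows this kind of change, so the expectation rests on the values of compound 1 alone. A modest weakening is expected, the step of a 2.3-fold higher number from compound 1 to compound 4 (0.37 log units; beyond the scatter) staying small. Compound 4 is thus estimated at 100 nM, in the range 30 nM to 400 nM.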

Compound 4, half-maximal inhibitory concentration: 12.4 nM
For compound 4 the middle estimate is 8.1-fold (0.91 log units) above the measured one, outside the stated range (below it).
By their numbers in this assay, from the lowest: compound 4; then compound 1; then compound 3; then compound 2.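

In this assay methylamino in place of 3-methoxyazetidin-1-yl on a carbonyl carbon brings a 3.5-fold lower number from compound 1 to compound 4 (0.54 log units; beyond the scatter) and thus shows that, on the core of compound 1, this position does not need the four-membered ring or its methoxy group. The change swaps 6 heavy atoms for 2 and adds a hydrogen-bond donor, and the two differences cannot be separated here. Nothing available explains the gain. Dimethylamino, which has no amide hydrogen, would bear on that question. As far as these compounds go, whether the same change holds on the core of compound 2 or compound 3 stays open.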